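Fluoro-for-hydrogen step on two aminoazole cores

The source may report more compounds than this note shows. Statements on the series, on what has been measured and on what is new or still open speak of the compounds shown alone.

Measured compounds:
- compound 1 `Fc1ccccc1Nc1nc(-c2ccccc2)cs1`: in an ADME assay on microsomes from liver (Homo sapiens) for metabolic stability, read by LC-MS, using NADPH (a higher number here means that the compound lasts longer, a lower number that the compound disappears faster), compound 1 gives 0.36 h
- compound 2 `Fc1cccc(-c2csc(Nc3ccccc3F)n2)c1`: in this assay compound 2 gives 0.38 h
- compound 3 `O=C(O)c1cccc(-c2cnc(Nc3ccccc3F)o2)c1`: in this assay compound 3 gives 4.32 h

Compound 3 gives the highest number of the three; its nearest neighbour is compound 2 and the gap to both compound 2 and compound 1 lies beyond the scatter. The cores of compound 1 and compound 3 differ in more than one place; the difference between the two cores is not broken down here.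

Within the first pair, the change fluoro in place of hydrogen on an aromatic carbon gives a 1.1-fold higher number from compound 1 to compound 2 (0.02 log units; within the scatter). The unmeasured compound 4 `O=C(O)c1cccc(-c2cnc(Nc3ccc(F)cc3F)o2)c1` is made from compound 3 by the change (fluoro in place of hydrogen on an aromatic carbon). This is the same kind of change as that from compound 1 to compound 2, not the same: in compound 2 the entering fluoro sits meta to a large group, whereas in compound 4 it sits meta to a fluoro group and para to a large group.

Going by the values given here, with only one earlier instance, and that one within the scatter, the expectation for compound 4 is a step close to nothing, a 1.0-fold lower number from compound 3 to compound 4 (0.00 log units; within the scatter), resting on a 1.1-fold higher number from compound 1 to compound 2 (0.02 log units; within the scatter). Compound 4 is therefore estimated at 4.3 h in this assay, with a likely range from 2.2 h to 8.6 h.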

Compound 4, half-life in the Homo sapiens assay: 4.65 h
Compound 4: middle estimate off by 1.1-fold (0.03 log units), on the low side, and the stated range covers the measured number.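

In the Homo sapiens assay compound 3 gives 4.32 h and compound 4 gives 4.65 h, so fluoro in place of hydrogen on an aromatic carbon gives a 1.1-fold higher number from compound 3 to compound 4 (0.03 log units; within the scatter), and set beside the earlier instance the step does not differ between the two cores: the same change on two cores in the Homo sapiens assay, a 1.1-fold higher number (0.02 log units; within the scatter) from compound 1 to compound 2 and a 1.1-fold higher number (0.03 log units; within the scatter) from compound 3 to compound 4, 1.0-fold (0.01 log units) apart, within the scatter of two such steps. Going by these compounds alone, on these two pairs, the change carries from the core of compound 1 to the core of compound 3 as a step within the scatter, even though in compound 4 the entering fluoro sits meta to a fluoro group and para to a large group, a different place from the one it takes in compound 2. This does not show that the change is neutral on other cores or at other places on these rings, as two pairs set no general rule, and in a physicochemical assay for solubility, using the shake flask method, measured as kinetic solubility, at pH 7.4 (a higher number here means a more soluble compound, a lower number a less soluble compound), compound 3 gives 55600 nM and compound 4 gives 69000 nM, so the same change gives a 1.2-fold higher number from compound 3 to compound 4 (0.09 log units; within the scatter), a single step with no second core to set beside it.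

Open, as far as these compounds go, is whether a group larger than fluoro at the same place, such as trifluoromethyl, a methoxy group or an amine, would also leave the half-life in the Homo sapiens assay unmoved. Also open, from the compounds shown here alone, is how an ester or an amide in place of the carboxylic acid would read in the Homo sapiens assay and the physicochemical assay.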